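A few compounds are considered here, and "the series" means these few. Any claim that something is new, unique, unknown or untested is made for them only; others in the source may bear on it.

Series in a functional assay on L1210 cells (Mus musculus) for inhibition, with a stated time of 96 h (a higher number here means a weaker inhibitor, a lower number a stronger inhibitor), so far:

- compound 1 `CNCCCNCCCNC`: 4800 nM
- compound 2 `CCNCCCNCCCN`: > 100000 nM

Compound 2 reads > 100000 nM in this assay, which is a limit of the assay and not a number. Going by the values given here, compound 1, at 4800 nM, is the only compound with a measured number. How far compound 2 lies past its limit is not known, so any step starting from it can be stated only loosely.

Compound 3 `CCNCCCNCCCNCC` is compound 2 with a single change: ethyl in place of hydrogen on an amine nitrogen. Among the compounds with values here, no measured step shows this change, so the expectation rests on the two values alone. A large step towards stronger inhibition is expected, well beyond the usual scatter. The reference for its size is compound 1 at 4800 nM, and a result near that level is expected, with a real chance that compound 3 stays weak. The estimate corresponds to an expected at least 20-fold lower number from compound 2 to compound 3 (1.30 log units; beyond the scatter) in this series. Compound 3 is estimated at 5000 nM, with an expected range of 1000 nM to 40000 nM in this read-out.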

Compound 3, half-maximal inhibitory concentration: 10000 nM
Beside the measured number, compound 3's estimate is 2.0-fold (0.30 log units) below it, within the range that was stated.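

In this assay, going by these compounds alone, ethyl in place of hydrogen on an amine nitrogen whose other neighbours are saturated chain carbon appears here for the first time as a single change, and it gives an at least 10-fold lower number from compound 2 to compound 3 (1.00 log units; beyond the scatter). With compound 3 at 10000 nM, the series shows that a free amino end, as carried by compound 2, is not required for a measurable number in this assay, and that this nitrogen accepts ethyl with a gain in inhibition. Compound 2 reads > 100000 nM, which is a limit of the assay and not a number, so only a minimum can be given for the size of the step: the limit of > 100000 nM in this assay, at which 1 of the 3 values shown sits.

On these data alone, the full size of the ethyl step remains open, and so does the question of whether the gain depends on the size of the group on this nitrogen. A propyl group, a longer chain or a benzyl group on this amine nitrogen lies outside the compounds shown, so it cannot be said whether the number would fall further or rise again with such groups.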